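The source may hold more compounds than are shown below. What is called first, only, known or untested is meant among the compounds shown, and "the series" means these compounds.

Three ureas built on one shared core have been examined in an assay on isolated protein for inhibition of STE20-like serine/threonine-protein kinase (Homo sapiens), read by thermal shift assay, tested at 10 uM; on this read-out lower numbers stand for weaker stabilisation of the target and higher numbers for stronger stabilisation of the target against heat. Compound 1 `CC(C)(C)c1cc(NC(=O)Nc2ccc(Cl)cc2)n(-c2ccc(C(F)(F)F)cc2)n1` gives 0.7 degrees C. Compound 2 `CC(C)(C)c1cc(NC(=O)Nc2ccc(Cl)cc2)n(-c2ccc(OC(F)(F)F)cc2)n1` gives 0.2 degrees C. Compound 3 `CC(C)(C)c1cc(NC(=O)Nc2ccc(Cl)cc2)n(-c2ccc(C#N)cc2)n1` gives 1.6 degrees C. The steps between them are modest at best: a number 0.50 degrees C lower from compound 1 to compound 2 (within the scatter), a number 0.90 degrees C higher from compound 1 to compound 3 (within the scatter), and only a number 1.4 degrees C higher from compound 2 to compound 3 (beyond the scatter). Compound 3 thus carries the highest of the three numbers, although its gap to compound 1 is within the scatter and only its gap to compound 2 lies beyond it. Compound 4 `CC(C)(C)c1cc(NC(=O)Nc2ccc(Cl)cc2)n(-c2ccc(S(C)(=O)=O)cc2)n1` is the next member of the set, and it differs from compound 3 by methylsulfonyl in place of cyano on an aromatic carbon. The group exchanged here is the same one that was varied in all three earlier steps, none of which moved this assay by more than a modest amount. The expected step is therefore a number 0.60 degrees C lower from compound 3 to compound 4 (within the scatter), small and of uncertain direction. On that basis compound 4 is estimated at 1 degrees C in this assay, with a likely range from -0.2 degrees C to 2.4 degrees C.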

Compound 4, shift of the target's melting temperature: 5.2 degrees C
Beside the measured number, compound 4's estimate is 4.2 degrees C below it, outside the stated range (above it).
By their numbers in this assay, from the lowest: compounds 2, 1 and 3 (each within the scatter of the next, the first and the last beyond it); then compound 4.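

At the position para to a large group on the aromatic ring, this assay turned out to respond well beyond the scatter, with a number 3.6 degrees C higher from compound 3 to compound 4 (beyond the scatter), a number 4.5 degrees C higher from compound 1 to compound 4 (beyond the scatter) and a number 5.0 degrees C higher from compound 2 to compound 4 (beyond the scatter). The exchanges among trifluoromethyl, trifluoromethoxy and cyano had shown no more than a modest step, so this position had looked nearly indifferent to the group it carried. Methylsulfonyl, with 4 heavy atoms and 2 hydrogen-bond acceptors against the 2 heavy atoms and 1 acceptor of cyano, separates compound 4 from all three others, and its steps to each lie beyond the scatter.

Nothing given here accounts for this rise. From the compounds shown here alone, it also remains open whether the higher number depends on the methyl group on the sulfonyl, or would persist with a primary sulfonamide or a longer chain such as ethylsulfonyl at this position.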